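The source may report more compounds than this note shows. Statements on the series, on what has been measured and on what is new or still open speak of the compounds shown alone.

Compound 1: `COc1ccc(C[S+]([O-])c2ncccc2C(=O)Nc2ccncc2)cc1` with 2.14 h
Compound 2: `COc1cc(OC)c(OC)cc1C[S+]([O-])c1ncccc1C(=O)Nc1ccncc1` with < 0.02 h

For the measured compounds named here, in an ADME assay (a higher number here means that the compound lasts longer, a lower number that the compound disappears faster), compound 1 gives 2.14 h, the only number measured so far. Compound 2 reaches only < 0.02 h, which is a limit of the assay and not a number. Going by the values given here, compound 1 therefore stands as the sole compound with a half-life that was actually measured, while compound 2 sits at the limit of < 0.02 h in this assay, at which 1 of the 2 values shown sits.

Compound 3 is `COCOCCOc1cc(OC)ccc1C[S+]([O-])c1ncccc1C(=O)Nc1ccncc1` and has not yet been measured in this assay. It differs from compound 1 in one place: 2-(methoxymethoxy)ethoxy in place of hydrogen on an aromatic carbon.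

Among the compounds with values here, no step between two measured compounds is available, so the size of the change to compound 3 can only be estimated. Because compound 2, the more heavily substituted ring, sits at the limit of < 0.02 h in this assay, at which 1 of the 2 values shown sits, the step in this assay is expected to go downward and beyond the scatter. The estimate means a step of a 5.4-fold lower number from compound 1 to compound 3 (0.73 log units; beyond the scatter). For compound 3 a half-life of 0.4 h is expected, with a range from 0.05 h to 2 h.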

Compound 3, half-life: < 0.02 h
Compound 3 ended at the assay's limit (the forecaster's own chance of this, stated with the estimate: 20%); middle value at least 20-fold (1.30 log units) away from the limit.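

In this assay, for the compounds shown here, the series now has its only step at a single place: 2-(methoxymethoxy)ethoxy in place of hydrogen on an aromatic carbon, ortho to a large group and meta to a methoxy group, gives an at least 100-fold lower number from compound 1 to compound 3 (2.02 log units; beyond the scatter). Going by these compounds alone, this shows that one substitution at this position is enough to cost nearly all of the half-life, which the earlier compounds could not show, as they offered no step at one place. The value of compound 3 is a limit of the assay and not a number, and the floor of the read-out now holds most of the compounds shown: the limit of < 0.02 h in this assay, at which 2 of the 3 values shown sit.

From the compounds shown here alone, the true size of the step therefore stays open. Going by these compounds, it is also open whether a much smaller substituent here, such as a single fluorine atom, or a chain ending in an amine, would shorten the half-life as far.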